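The compounds below may be only part of what the source reports. "The series", "measured", "known", "first", "only" and "open" are said of these compounds alone.

Measured compounds:
- Compound 1 `COc1cc(-c2nnc(SCC(=O)c3ccc(F)c(F)c3)n2N)cc(OC)c1OC` — in a functional assay on HepG2 cells (Homo sapiens) for antiproliferative activity, read by MTT assay, with a stated time of 48 h (a lower number here means a stronger inhibitor, a higher number a weaker inhibitor), compound 1 gives > 100000 nM, which is a limit of the assay and not a number.
- Compound 2 `COc1cc(-c2nnc(SCC(=O)Nc3ccccc3)n2N)cc(OC)c1OC` — compound 2 gives 49900 nM.
- Compound 3 `COc1cccc(NC(=O)CSc2nnc(-c3cc(OC)c(OC)c(OC)c3)n2N)c1` — compound 3 gives > 100000 nM, again a limit of the assay and not a number.

Compound 1 therefore stands only at a limit, and the limit of > 100000 nM in this assay, at which 2 of the 3 values shown sit, shows that two of the three values sit there, so its place among the three cannot be read more closely.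

Compound 4 `COc1cc(-c2nnc(SCC(=O)Nc3ccccc3F)n2N)cc(OC)c1OC` differs from compound 1 by (2-fluorophenyl)amino in place of 3,4-difluorophenyl on a carbonyl carbon. The measured steps that bear on this change are an at least 2.0-fold lower number from compound 1 to compound 2 (0.30 log units; that floor lies within the scatter), where an anilino replaced the same 3,4-difluorophenyl and a number appeared, a step that the two limits leave unreadable from compound 1 to compound 3, and an at least 2.0-fold higher number from compound 2 to compound 3 (0.30 log units; that floor lies within the scatter), where a methoxy added to the aromatic ring of the amide returned the value to the limit. Compound 4 carries a fluorine rather than a methoxy on that ring, so the closest guide is the step to compound 2, read with the caution that one end of it is a limit.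

For compound 4, the expected outcome is a value around 70000 nM, between 30000 nM and 150000 nM, corresponding to an expected step of an at least 1.4-fold lower number from compound 1 to compound 4 (0.15 log units; that floor lies within the scatter).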

Compound 4, half-maximal inhibitory concentration: 18700 nM
For compound 4 the middle estimate is 3.7-fold (0.57 log units) above the measured one, outside the stated range (below it).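

Until now the only substituted ring on the amide nitrogen was the 3-methoxyphenyl of compound 3, whose value is a limit of the assay, so any added group on that ring might have looked like a loss; compound 4 shows otherwise, with a 2.7-fold lower number from compound 2 to compound 4 (0.43 log units; beyond the scatter) in this assay. The change of the whole group gives an at least 5.3-fold lower number from compound 3 to compound 4 (0.72 log units; beyond the scatter), so 2-fluorophenyl and 3-methoxyphenyl do not behave alike here, although that step changes both the substituent and where it sits. Replacing the 3,4-difluorophenyl on the carbonyl carbon now gives a step beyond the scatter, an at least 5.3-fold lower number from compound 1 to compound 4 (0.72 log units; beyond the scatter), which the floor of the step to compound 2 could not show, yet this step, like the one from compound 3, is only a floor: the limit of > 100000 nM in this assay, at which 2 of the 4 values shown sit.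

The compounds shown do not separate the effect of the fluoro itself from that of its place on the ring, since each ring substituent appears at one place only. On these data alone, whether a chlorine or a methyl group in place of the fluoro would lower the number further, match it or lose it again remains open.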